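Fluorinated aroyl variant within a trimethoxyphenyl-triazolothiadiazine series

The compounds below may be only part of what the source reports. "The series", "measured", "known", "first", "only" and "open" are said of these compounds alone.

Compound 1 `COc1cc(-c2nnc3n2NC(c2ccco2)C(C(=O)c2cccs2)S3)cc(OC)c1OC` is the thiophen-2-yl ketone of the shared core; in a functional assay on PC-3 cells (Homo sapiens) for cytotoxicity, read by MTT assay, with a stated time of 48 h (a lower number here means a stronger inhibitor, a higher number a weaker inhibitor), compound 1 gives 46200 nM, the second highest of three numbers, within the scatter of compound 3 on one side and compound 2 on the other. Compound 2 `COc1cc(-c2nnc3n2NC(c2cccs2)C(C(=O)c2ccccc2)S3)cc(OC)c1OC` gives 86300 nM and compound 3 `COc1cc(-c2nnc3n2NC(c2cccs2)C(C(=O)c2ccc(F)cc2)S3)cc(OC)c1OC` gives 27400 nM. Compound 4 `COc1cc(-c2nnc3n2NC(c2ccco2)C(C(=O)c2ccc(F)c(F)c2)S3)cc(OC)c1OC` differs from compound 1 by 3,4-difluorophenyl in place of thiophen-2-yl on a carbonyl carbon. For the measured compounds named here, the one measured step that bears on this is a 3.1-fold lower number from compound 2 to compound 3 (0.50 log units; beyond the scatter), a single fluorine on the aroyl ring; the thiophene-to-phenyl swap itself is unmeasured as a lone change. A modest lowering is therefore expected, a 1.8-fold lower number from compound 1 to compound 4 (0.27 log units; within the scatter). Compound 4 is estimated at 25000 nM, range 10000 nM to 60000 nM.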

Compound 4, half-maximal inhibitory concentration: 36000 nM
Estimate against measurement, compound 4: 1.4-fold (0.16 log units) below, within the range that was stated.
By their numbers in this assay, from the lowest: compounds 3, 4, 1 and 2 (each within the scatter of the next, the first and the last beyond it).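

In this assay the carbonyl carbon takes a change of ring type, with thiophen-2-yl leaving and 3,4-difluorophenyl entering, and the result is a 1.3-fold lower number from compound 1 to compound 4 (0.11 log units; within the scatter). The two groups are therefore not separated here, whereas the earlier fluorine step on the aroyl ring, a 3.1-fold lower number from compound 2 to compound 3 (0.50 log units; beyond the scatter), was resolved. No measurement explains either result. From the compounds shown here alone, how plain phenyl or 4-fluorophenyl on this carbonyl carbon reads against the core of compound 1 stays open, as does the effect of an amine or a carboxylic acid on the aroyl ring.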